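Removing the Pyrazolyl Group from Compound 2

The source may hold more compounds than are shown below. What is called first, only, known or untested is meant among the compounds shown, and "the series" means these compounds.

Measured compounds:
compound 1, `COc1c(Cl)ccc2c1CCC2c1ncc[nH]1`, 24%
compound 2, `c1cc(-c2cn[nH]c2)c2c(c1)C(c1ncc[nH]1)CC2`, 84%

In a functional assay on CHO cells for agonist activity at Alpha-1A adrenergic receptor (Homo sapiens), read by FLIPR and calcium flux (on this read-out lower numbers stand for smaller maximal responses and higher numbers for larger maximal responses), compound 1 `COc1c(Cl)ccc2c1CCC2c1ncc[nH]1` gives 24%, while compound 2 `c1cc(-c2cn[nH]c2)c2c(c1)C(c1ncc[nH]1)CC2` gives 84%. Compound 2 stands highest of the two numbers; its nearest neighbour is compound 1, a gap beyond the usual scatter. The two differ in more than one place, so their values are only compared as they stand. Compound 3 `c1ccc2c(c1)CCC2c1ncc[nH]1` has not yet been measured. It differs from compound 2 as follows: hydrogen in place of 1H-pyrazol-4-yl on an aromatic carbon. For the measured compounds named here, no single-change step between measured compounds is known, so the direction rests on the structures alone; the account expects a drop from compound 2 to compound 3 in this assay of a number 39 percentage points lower from compound 2 to compound 3 (beyond the scatter), the 1H-pyrazol-4-yl being the one group that sets compound 2 apart from the unsubstituted core of compound 3. For compound 3 the estimated value is 45%, with a range from 10% to 85%.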

Compound 3, largest response reached (Emax), in percent of the reference or control that the assay uses: 54%
For compound 3 the middle estimate is 9 percentage points below the measured one; low and high end bracket the measured number.
By their numbers in this assay, from the lowest: compound 1; then compound 3; then compound 2.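

In this assay, for the compounds shown here, hydrogen in place of 1H-pyrazol-4-yl on an aromatic carbon gives a number 30 percentage points lower from compound 2 to compound 3 (beyond the scatter) and so provides the first reading of a single change at this position, which compound 1 and compound 2 could not offer. The response does not depend wholly on the 1H-pyrazol-4-yl: with hydrogen at this position, compound 3 still gives 54% in this assay on the unsubstituted core. Nothing given here explains the size or direction of this step.

The compounds shown leave open whether an amine, a carboxylic acid or a phenyl ring on the same aromatic carbon would match the response of compound 2. They also leave open whether a 1-methyl-1H-pyrazol-4-yl group would retain that response.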